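The source may hold more compounds than are shown below. What is called first, only, known or untested is meant among the compounds shown, and "the series" means these compounds.

Compound 1 `CCCCNc1nc(N)nc2cccc(C(=O)NC(C)C)c12`: in an ADME assay on HEK293 cells for agonist activity at Toll-like receptor 8 (Homo sapiens), read by a luciferase reporter, with a stated time of 6 h (a lower number here means that less compound is needed, a higher number that more compound is needed for the effect), compound 1 gives 15.6 uM.
Compound 2 `CCCCNc1nc(N)nc2cccc(C(=O)N(C)C(C)C)c12`: compound 2 gives > 25 uM, which is a limit of the assay and not a number.
Compound 3 `CCCCNc1nc(N)nc2cccc(C(=O)N[C@H](C)c3ccccc3)c12`: compound 3 gives > 25 uM, again a limit of the assay rather than a number.

Compound 3 therefore stands only at a limit; it shares that position with one other compound, as the limit of > 25 uM in this assay, at which 2 of the 3 values shown sit, shows. Going by the values given here, the step of an at least 1.6-fold higher number from compound 1 to compound 3 (0.20 log units; that floor lies within the scatter) is the one measured step that leads to compound 3 from a numbered value, and the step that the two limits leave unreadable from compound 2 to compound 3 gives no readable size.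

Compound 4 `CCCCNc1nc(N)nc2cccc(C(=O)N[C@@H](C)c3ccccc3)c12` is the partner of compound 3 in which (the two compounds have the same atoms and bonds and differ only in configuration as drawn: 1 of 1 stereo elements differ; a stereocentre at a saturated chain carbon is drawn R in compound 3 and S in compound 4). Among the compounds with values here, none of the measured steps involves a change of configuration alone, so they bear on this step only indirectly: they show that two of three close relatives of compound 1 sit at the limit, and compound 3 itself is one of them. Within the data shown here, with no measured step of this kind to lean on, the expected step of a number no higher from compound 3 to compound 4 (the limit leaves the size open) is none beyond the scatter, and compound 4 is expected most likely to be reported as a limit as well. The estimate for compound 4 in this assay is 25 uM, with a range from 10 uM to 60 uM.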

Compound 4, minimum effective concentration: > 25 uM
Compound 4 ended at the assay's limit; the forecaster's own chance of this, stated with the estimate: 65%; the middle value sits exactly at the limit.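

In this assay compound 4 gives > 25 uM, which is a limit of the assay and not a number. Compound 3 and compound 4 carry the two opposite drawings of the stereocentre in the 1-phenylethyl group, and neither drawing yields a number, so the steps from compound 3 and from compound 2 to compound 4 cannot be read, and the limit is now the common position of most of the compounds shown: the limit of > 25 uM in this assay, at which 3 of the 4 values shown sit. The only readable step is an at least 1.6-fold higher number from compound 1 to compound 4 (0.20 log units; that floor lies within the scatter), so even against the one compound that holds a number, a change beyond the scatter is not shown.

As far as these compounds go, whether the two configurations differ at all remains open, since this pair offers no size for a comparison of this kind: the fact that compounds 3 and 4 differ only in the configuration as drawn. Also open, from the compounds shown here alone, is how the amide would read with other groups on its nitrogen, such as a cyclopropyl group, a 2-hydroxyethyl group or a benzyl group without the methyl of the 1-phenylethyl group, and whether any of these would give a number rather than a limit.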